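Cytotoxicity of a new side chain on the shared core

A few compounds are considered here, and "the series" means these few. Any claim that something is new, unique, unknown or untested is made for them only; others in the source may bear on it.

Compound 1 `[N-]=[N+]=NCc1ncnc2c1ncn2[C@@H]1O[C@H](CO)[C@@H](O)[C@H]1O`: > 250000 nM
Compound 2 `O=c1ccccn1Cc1ncnc2c1ncn2[C@@H]1O[C@H](CO)[C@@H](O)[C@H]1O`: > 100000 nM
Compound 3 `OC[C@H]1O[C@@H](n2cnc3c(CSc4ccccc4)ncnc32)[C@H](O)[C@@H]1O`: > 100000 nM

All three compounds were tested in a functional assay on Huh-7 cells (Homo sapiens) for cytotoxicity, read by MTT assay, with a stated time of 3 days; on this read-out higher numbers stand for lower toxicity in this test and lower numbers for higher toxicity in this test. Compound 1 reaches only (the limit of > 250000 nM in this assay, at which 1 of the 3 values shown sits), a limit of the test and not a number. Compound 2 likewise sits at a limit, (the limit of > 100000 nM in this assay, at which 2 of the 3 values shown sit), and compound 3 sits at that same limit. Compound 1 therefore stands nowhere on a scale: none of the three values is an actual measurement.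

Compound 4 `O=C(O)CSCc1ncnc2c1ncn2[C@@H]1O[C@H](CO)[C@@H](O)[C@H]1O` differs from compound 1 by (carboxymethyl)sulfanyl in place of azido on a saturated chain carbon bound to an aromatic carbon. Within the data shown here, the steps that bear on a change at this position are a step that the two limits leave unreadable from compound 1 to compound 2 and a step that the two limits leave unreadable from compound 1 to compound 3; both are left unreadable by the two limits, as is a step that the two limits leave unreadable from compound 2 to compound 3. Nothing in these numbers points in either direction, so no step beyond the scatter is expected in this assay.

For compound 4 the estimate is 200000 nM, within 50000 nM to 500000 nM, most likely again reported only as a limit. The expected step is an at least 1.2-fold lower number from compound 1 to compound 4 (0.09 log units; that floor lies within the scatter).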

Compound 4, half-maximal cytotoxic concentration: > 100000 nM
Compound 4: a limit, no number; the forecaster's own chance of this, stated with the estimate: 85%; the middle value does not contradict the limit.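

In this assay compound 4 gives > 100000 nM, a limit of the test and not a number. Among these compounds, compound 1, compound 2 and compound 3 also stand at limits, so no step between them and compound 4 can be read. The compounds shown leave open whether any of these side chains on the shared core would give an actual number in this assay.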